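Cyclopropyl for methyl on the sulfonamide nitrogen

The compounds below may be only part of what the source reports. "The series", "measured", "known", "first", "only" and "open" are said of these compounds alone.

For the measured compounds named here, compound 1 `CCN(C/C=C/C#CC(C)(C)C)Cc1cccc(OCCN(C)S(=O)(=O)c2cccs2)c1` carries thiophen-2-yl on the sulfonyl sulfur and methyl on the sulfonamide nitrogen; in a functional assay on HepG2 cells for inhibition of squalene monooxygenase (Homo sapiens) (on this read-out higher numbers stand for weaker inhibition and lower numbers for stronger inhibition), compound 1 gives 60 nM, the lowest of the three numbers so far. Compound 2 `CCN(C/C=C/C#CC(C)(C)C)Cc1cccc(OCCN(C)S(=O)(=O)c2ccc(C#N)cc2)c1` gives 200 nM and compound 3 `CCN(C/C=C/C#CC(C)(C)C)Cc1cccc(OCCN(C)S(=O)(=O)c2cc3ccccc3s2)c1` gives 1800 nM. The steps seen, a 3.3-fold higher number from compound 1 to compound 2 (0.52 log units; beyond the scatter), a 30-fold higher number from compound 1 to compound 3 (1.48 log units; beyond the scatter) and a 9.0-fold higher number from compound 2 to compound 3 (0.95 log units; beyond the scatter), all exchange the group on the sulfonyl sulfur and leave the sulfonamide nitrogen untouched.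

Compound 4 `CCN(C/C=C/C#CC(C)(C)C)Cc1cccc(OCCN(C2CC2)S(=O)(=O)c2cccs2)c1` differs from compound 1 only at that nitrogen: cyclopropyl in place of methyl on a sulfonamide nitrogen. Going by the values given here, none of the measured steps touches this position, so none bears directly on the change; the thiophen-2-yl group that sets compound 1 apart is kept. Among the compounds with values here, with no comparable step to draw on, the expectation in this assay is a step within the usual scatter, a 1.3-fold higher number from compound 1 to compound 4 (0.12 log units; within the scatter), with uncertainty in either direction. Compound 4 is therefore estimated in this assay at 80 nM, with a range from 25 nM to 250 nM.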

Compound 4, half-maximal inhibitory concentration: 230 nM
The estimate for compound 4 lay 2.9-fold (0.46 log units) below the measured number, and the stated range covers the measured number.
By their numbers in this assay, from the lowest: compound 1; then compounds 2 and 4 (each within the scatter of the next); then compound 3.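

In this assay the sulfonamide nitrogen proves to be a position that responds to substitution: with thiophen-2-yl kept, cyclopropyl in place of methyl gives a 3.8-fold higher number from compound 1 to compound 4 (0.58 log units; beyond the scatter) and so weaker inhibition. For the compounds shown here, the earlier compounds changed only the group on the sulfonyl sulfur, so this is the first reading at the nitrogen, and the move from one heavy atom to three, with a three-membered ring, is not neutral here. No measurement at hand explains the loss.

Still open, from the compounds shown here alone, is whether the step follows the ring or simply the added carbon: ethyl or isopropyl on the sulfonamide nitrogen would separate the two, and hydrogen there would show whether any substituent is needed. Also open, going by these compounds, is whether the same step holds with 4-cyanophenyl on the sulfonyl sulfur.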